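The source may hold more compounds than are shown below. What is called first, only, known or untested is meant among the compounds shown, and "the series" means these compounds.

Measured in a functional assay on U-87MG ATCC cells for antiproliferative activity against U-87 MG (Homo sapiens), read by spectrophotometry, with a stated time of 2 days; a higher number here means a weaker inhibitor of growth, a lower number a stronger inhibitor of growth:
- compound 1 `COc1cc(Nc2ncc(C(F)(F)F)c(N3Cc4cccc(N(C)S(C)(=O)=O)c4C3)n2)c(OC)cc1Cl`: 6200 nM
- compound 2 `CN(c1cccc2c1CN(c1nc(Nc3ccc(Nc4ccccc4)cc3)ncc1C(F)(F)F)C2)S(C)(=O)=O`: 29800 nM
- compound 3 `Cc1cc(F)ccc1Nc1ncc(C(F)(F)F)c(N2Cc3cccc(N(C)S(C)(=O)=O)c3C2)n1`: > 30000 nM (a limit, not a number)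

Compound 3 has no numerical value, only the limit of the assay: the limit of > 30000 nM in this assay, at which 1 of the 3 values shown sits. Compound 4 `CN(c1cccc2c1CN(c1nc(Nc3ccc(C(F)(F)F)cc3)ncc1C(F)(F)F)C2)S(C)(=O)=O` has not yet been measured in this assay. It differs from compound 3 by the following change: 4-(trifluoromethyl)phenyl in place of 4-fluoro-2-methylphenyl on a nitrogen on an aromatic ring. In short, 4-(trifluoromethyl)phenyl replaces 4-fluoro-2-methylphenyl on a nitrogen on an aromatic ring.

One measured step changes the group at this place: an at least 4.8-fold higher number from compound 1 to compound 3 (0.68 log units; beyond the scatter). On these data alone, that step leaves the 4-chloro-2,5-dimethoxyphenyl group of compound 1 and ends at a limit, so its true size is unknown. It gives no direct measure of the exchange made here. Compound 2 also sits high in the series, with 29800 nM. Compound 1 is the only one of the three with a value well clear of the limit, and compound 4 does not carry its group.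

No change beyond the scatter is therefore expected in this assay, and compound 4 may again be reported only as a limit. The expected move is an at least 1.0-fold lower number from compound 3 to compound 4 (0.02 log units; that floor lies within the scatter). For compound 4 the estimated value is 28000 nM, with an expected range from 10000 nM to 50000 nM.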

Compound 4, concentration for 50% growth inhibition: > 30000 nM
Compound 4: only a limit was reported; the forecaster's own chance of this, stated with the estimate: 55%; middle value at least 1.0-fold (0.02 log units) away from the limit.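

In this assay compound 4 is reported only as a limit, > 30000 nM. With 4-(trifluoromethyl)phenyl in place of 4-chloro-2,5-dimethoxyphenyl on the nitrogen, the step is an at least 4.8-fold higher number from compound 1 to compound 4 (0.68 log units; beyond the scatter), so a second replacement at this place, after 4-fluoro-2-methylphenyl, also fails to keep the growth inhibition of compound 1. With trifluoromethyl in place of anilino on an aromatic carbon, the step is a number no lower from compound 2 to compound 4 (the limit leaves the size open). The step that links compound 4 to compound 3 cannot be read, and the limit is now reached more often at this position: the limit of > 30000 nM in this assay, at which 2 of the 4 values shown sit.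

Whether the chlorine or the two methoxy groups of compound 1 account for its measurable value stays open, since the compounds shown do not separate them, and the effect of an amine such as morpholine on this phenyl ring is also unknown. The relative order of the 4-(trifluoromethyl)phenyl and 4-fluoro-2-methylphenyl groups remains undetermined, so the exchange between them has no known size or direction in this series.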